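Compound 3 and the step to compound 4

The compounds below may be only part of what the source reports. "The series", "measured", "known", "first", "only" and "open" are said of these compounds alone.

In a functional assay on A549 cells (Homo sapiens) for antiproliferative activity, read by MTT assay, with a stated time of 72 h (a lower number here means a stronger inhibitor, a higher number a weaker inhibitor), three compounds sharing one core have been measured. Compound 1 (`COc1ccccc1-c1c(C(=O)c2cc(OC)c(OC)c(OC)c2)sc2ccccc12`) gives > 10000 nM, which is a limit. Compound 3 (`COc1ccc(-c2c(C(=O)c3cc(OC)c(OC)c(OC)c3)sc3ccccc23)cc1C`) gives > 10000 nM, also a limit, and so stands at the limit of > 10000 nM in this assay, at which 2 of the 3 values shown sit. Compound 2 (`COc1ccc(-c2c(C(=O)c3cc(OC)c(OC)c(OC)c3)sc3ccccc23)c(OC)c1`) gives 5800 nM. The measured steps are an at least 1.7-fold lower number from compound 1 to compound 2 (0.23 log units; that floor lies within the scatter), an at least 1.7-fold higher number from compound 2 to compound 3 (0.23 log units; that floor lies within the scatter) and a step that the two limits leave unreadable from compound 1 to compound 3. Compound 4 (`COc1ccc(Nc2c(C(=O)c3cc(OC)c(OC)c(OC)c3)sc3ccccc23)cc1`) differs from compound 3 at one aromatic carbon: (4-methoxyphenyl)amino in place of 4-methoxy-3-methylphenyl on an aromatic carbon. Within the data shown here, no measured step covers this exchange, and it may also stay at the limit. Resting on an at least 1.7-fold higher number from compound 2 to compound 3 (0.23 log units; that floor lies within the scatter), only a small move is expected. The expected size is an at least 2.0-fold lower number from compound 3 to compound 4 (0.30 log units; that floor lies within the scatter), toward a lower number. For compound 4 the estimated value is 5000 nM, with an expected range from 600 nM to 20000 nM.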

Compound 4, half-maximal inhibitory concentration: 9300 nM
Estimate against measurement, compound 4: 1.9-fold (0.27 log units) below; measured number inside the range.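

At this aromatic carbon, (4-methoxyphenyl)amino, which brings a hydrogen-bond donor that the aryl groups lack, reads level with 2,4-dimethoxyphenyl: the exchange gives a 1.6-fold higher number from compound 2 to compound 4 (0.21 log units; within the scatter). Against the other two compounds the steps are an at least 1.0-fold lower number from compound 3 to compound 4 (0.03 log units; that floor lies within the scatter) and an at least 1.0-fold lower number from compound 1 to compound 4 (0.03 log units; that floor lies within the scatter), so neither shows a real gain. Compound 1 and compound 3 are known only as limits: the limit of > 10000 nM in this assay, at which 2 of the 4 values shown sit.

Going by these compounds, what the amine hydrogen itself contributes stays open. So does whether an ether link, a carbonyl link or a longer chain in place of the amino link would read any differently.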